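Phenyl for methyl on the pendant ring: compound 4 outlook

The compounds below may be only part of what the source reports. "The series", "measured", "known", "first", "only" and "open" are said of these compounds alone.

Of the compounds shown here, three have been measured in an assay for inhibition of inositol hexakisphosphate kinase 2 (Homo sapiens), read by colorimetric assay, coupled enzyme assay and malachite green, with a stated time of 120 min, in the presence of a further agent that is not named here; on this read-out lower numbers stand for stronger inhibition and higher numbers for weaker inhibition. Compound 1 `CN(C)C(=O)/C=C/c1ccc2noc(-c3ccccc3)c2c1` gives 40300 nM. Compound 2 `CNC(=O)/C=C/c1ccc2noc(-c3ccccc3)c2c1` gives 58200 nM. Among the compounds with values here, the only single-point step measured so far is a 1.4-fold higher number from compound 1 to compound 2 (0.16 log units; within the scatter), a change at the amide nitrogen. Compound 3 `Cc1ccc(-c2onc3ccc(/C=C/C(=O)O)cc23)cc1` gives 6510 nM, the lowest number of the three, and its gap to each of the other two lies beyond the scatter. Within the data shown here, compound 3 differs from both of them at the acid end as well as on the pendant ring, so no single step is drawn to it.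

Compound 4 `O=C(O)/C=C/c1ccc2noc(-c3ccc(-c4ccccc4)cc3)c2c1` has not been measured. It differs from compound 3 by phenyl in place of methyl on an aromatic carbon. Among the measured compounds shown here, no measured step touches the pendant ring, so the data give no direction for this change, only the scale of variation seen across the series. Compound 4 is therefore estimated to move by about a 1.3-fold lower number from compound 3 to compound 4 (0.11 log units; within the scatter), that is, to stay near compound 3. Compound 4 is expected to give about 5000 nM in this assay. The range for compound 4 is estimated from 1200 nM to 20000 nM.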

Compound 4, half-maximal inhibitory concentration: 74 nM
Beside the measured number, compound 4's estimate is 68-fold (1.83 log units) above it; measured number outside the range, below it.
By their numbers in this assay, from the lowest: compound 4; then compound 3; then compounds 1 and 2 (each within the scatter of the next).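

In this assay, within the data shown here, phenyl in place of methyl on an aromatic carbon, para to a large group, gives an 88-fold lower number from compound 3 to compound 4 (1.94 log units; beyond the scatter) and is the first measured step on the pendant ring. This position responds far more strongly than the amide nitrogen, where a 1.4-fold higher number from compound 1 to compound 2 (0.16 log units; within the scatter) stays within the scatter, although the two steps sit on different compounds. Nothing available accounts for the size of the step at the pendant ring.

The compounds shown do not settle whether the aromatic ring itself is needed at this position, or whether a cyclohexyl, a pyridyl or a longer alkyl chain would serve as well. They also leave open whether the phenyl gain holds when the carboxylic acid is replaced by the dimethyl amide of compound 1.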